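Triazole aryl swap in the furanone series: bromo to hydroxyl

The compounds below may be only part of what the source reports. "The series", "measured", "known", "first", "only" and "open" are said of these compounds alone.

Compound 1 `O=C1O/C(=C\Cn2cc(-c3ccc(Br)cc3)nn2)C(OCc2ccccc2)=C1OCc1ccccc1` reaches only a limit in a functional assay on CFPAC-1 cells (Homo sapiens) for antiproliferative activity, read by MTT assay, with a stated time of 72 h (a lower number here means a stronger inhibitor, a higher number a weaker inhibitor), reported as > 100000 nM. Compound 3 `Cc1ccc(-c2cn(C[C@H](O)[C@H]3OC(=O)C(OCc4ccccc4)=C3OCc3ccccc3)nn2)cc1` likewise gives only a limit in this assay, > 100000 nM. Among the measured compounds shown here, compound 2 `CC(C)(C)c1cn(C[C@H](O)[C@H]2OC(=O)C(OCc3ccccc3)=C2OCc2ccccc2)nn1` is the sole member with a number, giving 54900 nM in this assay. For the measured compounds named here, the one step between measured compounds that differ in a single place is an at least 1.8-fold higher number from compound 2 to compound 3 (0.26 log units; that floor lies within the scatter), which exchanges the group on the triazole ring and ends at a limit. Going by the values given here, two of the three values so far sit at the limit of > 100000 nM in this assay, at which 2 of the 3 values shown sit.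

Compound 4 `O=C1O/C(=C\Cn2cc(-c3cccc(O)c3)nn2)C(OCc2ccccc2)=C1OCc1ccccc1` differs from compound 1 by 3-hydroxyphenyl in place of 4-bromophenyl on an aromatic carbon. Among the compounds with values here, no measured step tests a bromine-to-hydroxyl exchange on that phenyl ring, and the step from compound 2 to compound 3 concerns a different group, so no direction can be read from the numbers. Since compound 1 stands at a limit, compound 4 is expected to remain near that limit as well, with an estimate of 100000 nM, ranging from 40000 nM to 250000 nM. The step of a number no higher from compound 1 to compound 4 (the limit leaves the size open) is therefore expected to be none beyond the scatter.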

Compound 4, half-maximal inhibitory concentration: 33700 nM
Estimate against measurement, compound 4: 3.0-fold (0.47 log units) above, outside the stated range (below it).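

In this assay, among the compounds shown here, the aryl group on the triazole gives the first step in this set that can be read as beyond the scatter, an at least 2.9-fold lower number from compound 1 to compound 4 (0.47 log units; beyond the scatter), whereas the floor of the earlier step lay within it. With 3-hydroxyphenyl on this aromatic carbon of the core of compound 1, the series gains a number where 4-bromophenyl gave none, so this position can respond to the aryl group it carries. The step still has a floor and no upper size, as compound 1 stands at a limit: the limit of > 100000 nM in this assay, at which 2 of the 4 values shown sit.

The exchange alters both the substituent and its place on the phenyl ring, so the compounds shown do not separate these two changes. Going by these compounds, how a methoxy or an amino group on that phenyl ring would read in this assay also remains open.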